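The source may hold more compounds than are shown below. What is called first, only, known or untested is meant among the compounds shown, and "the series" means these compounds.

In an assay on Prostate gland for inhibition of steroid 5-alpha-reductase (Rattus norvegicus) (a lower number here means a stronger inhibitor, a higher number a weaker inhibitor), compound 2 `CCCCC(C)n1ccc2cc(/C(C)=C/C(=O)Nc3ccccc3OCCCC(=O)O)ccc21` gives 6 nM, the lowest of the three numbers available. Compound 1 `CCCCCCCn1ccc2cc(/C(C)=C/C(=O)Nc3ccccc3OCCCC(=O)O)ccc21` gives 120 nM, and compound 3 `C/C(=C\C(=O)Nc1ccccc1OCCCC(=O)O)c1ccc2c(ccn2Cc2ccc(C)cc2)c1` gives 88 nM. The step of a 20-fold lower number from compound 1 to compound 2 (1.30 log units; beyond the scatter) and the step of a 15-fold higher number from compound 2 to compound 3 (1.17 log units; beyond the scatter) both set compound 2 well apart from the other two, whereas the step of a 1.4-fold lower number from compound 1 to compound 3 (0.13 log units; within the scatter) shows that a 4-methylphenyl and a hexyl on the saturated chain carbon bound to the aromatic nitrogen give much the same number.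

Compound 4 `C/C(=C\C(=O)Nc1ccccc1OCCCC(=O)O)c1ccc2c(ccn2Cc2ccc(C(C)(C)C)cc2)c1` differs from compound 2 in one place: 4-(tert-butyl)benzyl in place of 1-methylpentyl on an aromatic nitrogen. The step that bears most directly on this change is a 15-fold higher number from compound 2 to compound 3 (1.17 log units; beyond the scatter), where a 4-methylbenzyl on the aromatic nitrogen took the place of the same 1-methylpentyl. Within the data shown here, compound 4 again carries a benzyl on that nitrogen, differing from compound 3 only in the group on the benzyl ring, and no measured step tells how one benzyl compares with another. A loss of a size comparable to that seen from compound 2 to compound 3 is therefore expected. Compound 4 is estimated at 60 nM, with a range from 20 nM to 200 nM, which is an expected step of a 10-fold higher number from compound 2 to compound 4 (1.00 log units; beyond the scatter).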

Compound 4, half-maximal inhibitory concentration: 170 nM
Estimate against measurement, compound 4: 2.8-fold (0.45 log units) below; measured number inside the range.
By their numbers in this assay, from the lowest: compound 2; then compounds 3, 1 and 4 (each within the scatter of the next).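

In this assay the 4-(tert-butyl)benzyl on the aromatic nitrogen also falls far short of the 1-methylpentyl, with the step of a 28-fold higher number from compound 2 to compound 4 (1.45 log units; beyond the scatter), so the gap to compound 2 now holds for two benzyl groups and not just one. Among these compounds, the step of a 1.9-fold higher number from compound 3 to compound 4 (0.29 log units; within the scatter) gives the first direct comparison of one benzyl with another and lies within the scatter, so tert-butyl and methyl on that aromatic carbon cannot be told apart here, and the step of a 1.4-fold higher number from compound 1 to compound 4 (0.15 log units; within the scatter) likewise leaves this benzyl level with the heptyl. Nothing available gives a reason for these numbers.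

As far as these compounds go, it remains open whether the low number of compound 2 goes with the branch in the 1-methylpentyl or with the length of its chain, a question that a hexyl or a 1-ethylbutyl on the aromatic nitrogen would help to separate. From the compounds shown here alone, it is also open whether a benzyl with nothing on its ring, or with a methoxy or a chlorine there, would stay with compound 3 and compound 4.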